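Moving one methoxy group on compound 1

A few compounds are considered here, and "the series" means these few. Any claim that something is new, unique, unknown or untested is made for them only; others in the source may bear on it.

Measured so far in a functional assay on MCF7 cells (Homo sapiens) for cytotoxicity, read by MTT assay, with a stated time of 72 h; a lower number here means a stronger inhibitor, a higher number a weaker inhibitor
compound 1 `COc1ccc(/C=C/C(=O)Nc2cc3c(Nc4ccc(F)c(Cl)c4)ncnc3cc2O[C@H]2CCOC2)c(OC)c1` gives 28600 nM
compound 2 `COc1ccc(/C=C/C(=O)Nc2cc3c(Nc4ccc(F)c(Cl)c4)ncnc3cc2OC)cc1` reads "not active" (no number reported)
compound 3 `COc1ccc(/C=C/C(=O)Nc2cc3c(Nc4ccc(F)c(Cl)c4)ncnc3cc2OC)c(OC)c1` gives 36600 nM

Only compound 1 and compound 3 have numbers, and these lie within the scatter of each other (a 1.3-fold higher number from compound 1 to compound 3 (0.11 log units; within the scatter)). Compound 1 therefore stands level with compound 3, while compound 2 gave no number.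

The next molecule, compound 4 (`COc1ccc(OC)c(/C=C/C(=O)Nc2cc3c(Nc4ccc(F)c(Cl)c4)ncnc3cc2O[C@H]2CCOC2)c1`), has 2,5-dimethoxyphenyl in place of 2,4-dimethoxyphenyl on a double-bonded chain carbon bound to a double-bonded chain carbon. The atoms are the same, joined differently.

Among the measured compounds shown here, no measured step changes this position pattern. For the measured compounds named here, the one measured step alters another part of the molecule and stays within the scatter. Compound 3 gives a number (36600 nM) and compound 2 reads differently ("not active" (no number reported)). These two differ on the dimethoxyphenyl ring, so compound 4 may also give no number.

No step beyond the scatter is expected in this assay, and no direction can be favoured. The expected step is small (a 1.0-fold higher number from compound 1 to compound 4 (0.02 log units; within the scatter)). The estimate for compound 4 is 30000 nM (estimated range 12000 nM to 70000 nM).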

Compound 4, half-maximal inhibitory concentration: 36300 nM
Compound 4: middle estimate off by 1.2-fold (0.08 log units), on the low side; measured number inside the range.
By their numbers in this assay, from the lowest: compounds 1, 4 and 3 (each within the scatter of the next).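

In this assay, replacing 2,4-dimethoxyphenyl with 2,5-dimethoxyphenyl gives a 1.3-fold higher number from compound 1 to compound 4 (0.10 log units; within the scatter) and so stays within the scatter, even though the same atoms are joined differently. Among the compounds shown here, this is the first measured step on the dimethoxyphenyl ring that yields two numbers, and it shows that this particular rearrangement of the two methoxy groups leaves the reading unresolved from that of compound 1. No measurement in hand accounts for this result.

The compounds shown leave open whether any other group on this ring could produce a step beyond the scatter, such as an amine or a carboxylic acid in place of a methoxy group. They also leave open whether a longer chain in place of the methoxy groups would change the reading.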